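Fluoro for chloro on a phenyl ring

This account rests on a few compounds, and the source may have more. Where it says the series, first, only, none or still open, it means among the compounds named here.

Compound 1 `COc1ccc(-c2nsc3c2NC(=O)CC3c2cccc(OC)c2)cc1` gives 1480 nM
Compound 2 `COc1ccc(-c2nsc3c2NC(=O)CC3c2cccc(Cl)c2)cc1` gives 1300 nM

For the measured compounds named here, in a functional assay on Caov-3 cells (Homo sapiens) for antiproliferative activity, read by CellTiter-Glo, with a stated time of 96 h (on this read-out higher numbers stand for weaker inhibition and lower numbers for stronger inhibition), compound 2 stands at 1300 nM on the numbers so far, level with compound 1 within the usual scatter. Compound 3 `COc1ccc(-c2nsc3c2NC(=O)CC3c2cccc(F)c2)cc1` has not yet been measured. It departs from compound 2 by a single change fluoro in place of chloro on an aromatic carbon and in plain words this is fluoro in place of chloro on an aromatic carbon, meta to a large group. Going by the values given here, only one measured step bears on this swap: a 1.1-fold lower number from compound 1 to compound 2 (0.06 log units; within the scatter) is what chloro in place of methoxy on that same aromatic carbon gave. One small step is thin evidence, yet it offers no reason to expect a real shift in this assay from this change. The expected step is a 1.1-fold higher number from compound 2 to compound 3 (0.03 log units; within the scatter) and thus none beyond the scatter. Compound 3 is estimated at 1400 nM with an expected range of 700 nM to 2800 nM in this read-out.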

Compound 3, half-maximal inhibitory concentration: > 2000 nM
Compound 3: only a limit was reported; the forecaster's own chance of this, stated with the estimate: 2%; middle value at least 1.4-fold (0.15 log units) from the limit.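

Compound 3 is reported only as a limit: the limit of > 2000 nM in this assay, at which 1 of the 3 values shown sits. Read against its neighbours, fluoro in place of chloro gives an at least 1.5-fold higher number from compound 2 to compound 3 (0.18 log units; that floor lies within the scatter), and fluoro in place of methoxy gives an at least 1.3-fold higher number from compound 1 to compound 3 (0.13 log units; that floor lies within the scatter). The earlier pair showed chloro and methoxy level at this position, whereas fluoro may match them or may fall well behind them, so these floors neither establish a real loss nor rule one out.

On these data alone, the true size of both steps stays open, and with it the question of whether this small swap matters at all on this position of the 3-substituted phenyl ring. Also open, as far as these compounds go, is how an amine, a carboxylic acid or a longer chain on the same aromatic carbon would read in this assay.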